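The compounds below may be only part of what the source reports. "The series", "measured", "known", "first", "only" and "open" are said of these compounds alone.

For the measured compounds named here, compound 2 `Clc1ccc(-c2cn3ccnc3c(-c3ccc4ncn(C5CCCCC5)c4c3)n2)cc1` gives 27.6% in a functional assay on T47D cells (Homo sapiens) for inhibition, read by sulforhodamine B assay, with a stated time of 48 h, tested at 10 uM (a higher number here means more inhibition at the concentration tested (going by the name of the read-out), a lower number less inhibition), the higher of the two numbers measured so far, while compound 1 `c1ccc(-c2cn3ccnc3c(-c3ccc4ncn(C5CCCCC5)c4c3)n2)cc1` gives -11.1% in this assay. Going by the values given here, the only measured step, a number 38.7 percentage points higher from compound 1 to compound 2 (beyond the scatter), came with chloro in place of hydrogen on an aromatic carbon. Compound 3 `Brc1ccc(-c2cn3ccnc3c(-c3ccc4ncn(C5CCCCC5)c4c3)n2)cc1` differs from compound 2 by bromo in place of chloro on an aromatic carbon. Among the compounds with values here, no measured step bears directly on this change, so the expectation rests on compound 2 alone. Compound 3 is therefore expected to show a step of a number 4.4 percentage points higher from compound 2 to compound 3 (within the scatter), not beyond the scatter. The estimated value of compound 3 is 32%, with a range from 12% to 52%.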

Compound 3, a percentage reported as inhibition, at one concentration (the size of the read-out at that concentration, not a potency): 55%
For compound 3 the middle estimate is 23 percentage points below the measured one; the measured number lies above the stated range.
By their numbers in this assay, from the lowest: compound 1; then compound 2; then compound 3.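

In this assay the halogen at this place is not interchangeable: bromo in place of chloro gives a number 27.4 percentage points higher from compound 2 to compound 3 (beyond the scatter), so which halogen sits there matters, not only that one does. Bromo in place of hydrogen gives a number 66.1 percentage points higher from compound 1 to compound 3 (beyond the scatter), against a number 38.7 percentage points higher from compound 1 to compound 2 (beyond the scatter) for chloro in place of hydrogen. Nothing available explains this difference between the two halogens. The compounds shown leave open whether iodo, methoxy or an amine on this carbon would go beyond compound 3, and whether 4-chlorophenyl to 4-bromophenyl gives a similar step on another core.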